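The source may hold more compounds than are shown below. What is called first, only, known or untested is meant among the compounds shown, and "the series" means these compounds.

For the measured compounds named here, in a functional assay on A549 cells (Homo sapiens) for inhibition, read by MTT assay, with a stated time of 24 h (on this read-out lower numbers stand for stronger inhibition and higher numbers for weaker inhibition), compound 2 `CC(=O)c1ccc(/C=C/[C@@H]2CCCCN2)cc1` gives 3.69 ug/mL, the smaller of the two numbers in hand, though the only neighbour sits within the scatter: compound 1 `CCc1ccc(/C=C/[C@@H]2CCCCN2)cc1` gives 5.94 ug/mL, and the step of a 1.6-fold lower number from compound 1 to compound 2 (0.21 log units; within the scatter) is within the scatter. Compound 3 `C(=C/[C@@H]1CCCCN1)\c1ccccc1` is not yet measured. The change from compound 2 is hydrogen in place of acetyl on an aromatic carbon. Going by the values given here, only one measured step bears on this position: a 1.6-fold lower number from compound 1 to compound 2 (0.21 log units; within the scatter), in which acetyl took the place of ethyl on an aromatic carbon and the number barely moved. Removing the acetyl altogether is related but not identical, so compound 3 is taken to land near either neighbour. No step beyond the scatter is therefore expected in this assay, in either direction. For compound 3 the expected value is 5 ug/mL (range 2.5 ug/mL to 10 ug/mL). This estimate for compound 3 means an expected step of a 1.4-fold higher number from compound 2 to compound 3 (0.13 log units; within the scatter).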

Compound 3, half-maximal inhibitory concentration: 9.99 ug/mL
Compound 3: the middle estimate sits 2.0-fold (0.30 log units) below what was measured; the measured number falls inside the stated range.
By their numbers in this assay, from the lowest: compounds 2, 1 and 3 (each within the scatter of the next, the first and the last beyond it).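

In this assay, for the compounds shown here, the step of a 2.7-fold higher number from compound 2 to compound 3 (0.43 log units; beyond the scatter) is the first one at this aromatic carbon to lie beyond the scatter, although it is modest and rests on a single pair. Replacing ethyl with hydrogen gives the step of a 1.7-fold higher number from compound 1 to compound 3 (0.23 log units; within the scatter) and stays within the scatter, so only removal of acetyl separates two compounds at this position, while acetyl and ethyl themselves remain within the scatter of each other. Nothing available explains why removing acetyl gives a step beyond the scatter while removing ethyl does not.

Going by these compounds, whether the step beyond the scatter belongs to acetyl alone or extends to other groups remains open, since an amine, a carboxylic acid or a longer chain at this position would be needed to test it. On these data alone, how far the pattern holds on changes elsewhere in the shared core also remains unknown.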